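The source may hold more compounds than are shown below. What is called first, only, known or untested is meant among the compounds shown, and "the series" means these compounds.

Measured in an ADME assay on NHDF cells (Homo sapiens) for antiproliferative activity; on this read-out lower numbers stand for stronger inhibition of growth and higher numbers for weaker inhibition of growth:
compound 1 `COc1ccc(-c2cc(N3CCC(CNS(N)(=O)=O)CC3)ncn2)cc1` gives 77000 nM.
compound 2 `COc1ccccc1-c1cc(N2CCC(CNS(N)(=O)=O)CC2)ncn1` gives > 100000 nM, which is a limit of this assay and not a number.

Where compound 2 stands: its value is a limit, (the limit of > 100000 nM in this assay, at which 1 of the 2 values shown sits), so only a floor is known for it in this assay. Among the compounds with values here, the one measured step in the pair, an at least 1.2-fold higher number from compound 1 to compound 2 (0.11 log units; that floor lies within the scatter), moves the methoxy group from one position of the phenyl ring to another; its floor sits within the scatter, so no change beyond the scatter is established between compound 1 and compound 2.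

Compound 3 `NS(=O)(=O)NCC1CCN(c2cc(-c3ccccc3Cl)ncn2)CC1` differs from compound 2 by chloro in place of methoxy on an aromatic carbon. Within the data shown here, no measured step tracks an exchange of methoxy for chloro, and the single measured step is a positional change that itself stayed within the scatter. Among the measured compounds shown here, nothing among the measured compounds therefore speaks for a shift beyond the scatter in either direction in this assay. The expected step that the limit leaves unreadable from compound 2 to compound 3 is accordingly close to none. Compound 3 is estimated at 110000 nM, with a range from 40000 nM to 300000 nM, and a limit rather than a number is the more likely outcome for compound 3.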

Compound 3, concentration for 50% growth inhibition: 93000 nM
For compound 3 the middle estimate is 1.2-fold (0.07 log units) above the measured one, within the range that was stated.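

In this assay compound 3, with chloro on an aromatic carbon ortho to a large group, gives 93000 nM, so a group at this place now has a number rather than a limit. Compound 2 stands at a limit of the assay and not at a number: the limit of > 100000 nM in this assay, at which 1 of the 3 values shown sits.

The exchange of methoxy for chloro reads as an at least 1.0-fold lower number from compound 2 to compound 3 (0.03 log units; that floor lies within the scatter), and the change of 4-methoxyphenyl to 2-chlorophenyl reads as a 1.2-fold higher number from compound 1 to compound 3 (0.08 log units; within the scatter), so neither step establishes a change beyond the scatter in this assay.

What an amine or a carboxylic acid on this aromatic carbon, or a longer chain in place of the methoxy, would do to growth inhibition remains open, as the compounds shown carry only methoxy and chloro on the phenyl ring. Also open, on these data alone, is how far past its limit compound 2 lies, and with it the true size of the exchange of methoxy for chloro at this place.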